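Chloro in place of methoxy: expectation for compound 4

This account rests on a few compounds, and the source may have more. Where it says the series, first, only, none or still open, it means among the compounds named here.

The series shares one core. Compound 1 `COc1ncc(-c2ccc3nc(NC(=O)NC4CC4)sc3c2)cc1NS(=O)(=O)c1ccc(F)cc1` carries a cyclopropylcarbamoyl group, compound 2 `COc1ncc(-c2ccc3nc(NC4CC4)sc3c2)cc1NS(=O)(=O)c1ccc(F)cc1` a cyclopropyl group and compound 3 `COc1ncc(-c2ccc3nc(NC(=O)NCCN4CCCC4)sc3c2)cc1NS(=O)(=O)c1ccc(F)cc1` a (2-(pyrrolidin-1-yl)ethyl)carbamoyl group. In a functional assay on HCT-116 cells (Homo sapiens) for antiproliferative activity, read by MTT assay, with a stated time of 72 h (on this read-out higher numbers stand for weaker inhibition and lower numbers for stronger inhibition), compound 1 gives 470 nM, compound 2 gives 1560 nM and compound 3 gives 310 nM. Compound 1 thus stands second highest of the three numbers; its nearest neighbour is compound 3, with a 1.5-fold lower number from compound 1 to compound 3 (0.18 log units; within the scatter), while a 3.3-fold higher number from compound 1 to compound 2 (0.52 log units; beyond the scatter) and a 5.0-fold lower number from compound 2 to compound 3 (0.70 log units; beyond the scatter) set the wider span of the set.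

Compound 4 `O=C(Nc1nc2ccc(-c3cnc(Cl)c(NS(=O)(=O)c4ccc(F)cc4)c3)cc2s1)NC1CC1` differs from compound 1 in one place: chloro in place of methoxy on an aromatic carbon. Among the compounds with values here, none of the measured steps touches this place; all three alter the group on the nitrogen on an aromatic ring, and the methoxy group is unchanged across compounds 1, 2 and 3. Within the data shown here, no measured step therefore bears on this change, and no direction can be read from the numbers. The expected step is a 1.1-fold higher number from compound 1 to compound 4 (0.03 log units; within the scatter), which is none beyond the scatter. Compound 4 is estimated at 500 nM in this assay, with a range from 180 nM to 1500 nM.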

Compound 4, half-maximal inhibitory concentration: 1750 nM
Estimate against measurement, compound 4: 3.5-fold (0.54 log units) below; measured number above the stated range.
By their numbers in this assay, from the lowest: compounds 3 and 1 (each within the scatter of the next); then compounds 2 and 4 (each within the scatter of the next).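

In this assay, the position on the aromatic carbon next to the ring nitrogen, ortho to a ((4-fluorophenyl)sulfonyl)amino group, responds to substitution: chloro in place of methoxy gives a 3.7-fold higher number from compound 1 to compound 4 (0.57 log units; beyond the scatter). Within the data shown here, compound 1, compound 2 and compound 3 all keep the methoxy group and differ only in the group on the nitrogen on an aromatic ring, so this pair is the first reading of the position and shows that the variation is not confined to that nitrogen; within this one pair, methoxy gives the lower number and so the stronger inhibition. Nothing available explains the step, and the size of the change cannot be assigned to any property of either group.

A single pair cannot separate the loss of methoxy from the arrival of chloro, and hydrogen, fluoro, ethoxy or a dimethylamino group at this position would show whether methoxy itself is what matters. From the compounds shown here alone, it also remains open whether the same step would appear with the (2-(pyrrolidin-1-yl)ethyl)carbamoyl group of compound 3 on the shared core.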